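The compounds below may be only part of what the source reports. "The series", "measured", "known", "first", "only" and "open" are said of these compounds alone.

Measured in a functional assay on MDA-MB-435S cells (Homo sapiens) for antiproliferative activity, read by MTT assay, with a stated time of 72 h; on this read-out higher numbers stand for weaker inhibition and lower numbers for stronger inhibition:
- Compound 1 `CN1CCN(/C=C2\Oc3ccccc3C2=O)CC1`: 40300 nM
- Compound 2 `CN1CCN(/C=C2\Oc3ccccc3C2=O)C(c2ccccc2)C1`: > 50000 nM

In this assay, among the measured compounds shown here, compound 1 gives 40300 nM, the only exact number so far. Compound 2 reads > 50000 nM, which is a limit of the assay and not a number.

Compound 3 `O=C1/C(=C/N2CCN(c3ccccc3)CC2)Oc2ccccc21` is not yet measured. It differs from compound 1 by phenyl in place of methyl on an amine nitrogen in a ring. For the measured compounds named here, the one measured step, an at least 1.2-fold higher number from compound 1 to compound 2 (0.09 log units; that floor lies within the scatter), also brings in phenyl, though there it is hydrogen that leaves, not methyl. It is only a loose guide, so no change beyond the scatter is expected. The expected step is a 1.1-fold lower number from compound 1 to compound 3 (0.03 log units; within the scatter). For compound 3 the estimated value is 38000 nM, with an expected range of 14000 nM to 50000 nM.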

Compound 3, half-maximal inhibitory concentration: 25100 nM
The estimate for compound 3 lay 1.5-fold (0.18 log units) above the measured number; measured number inside the range.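

Replacing methyl with phenyl on the amine nitrogen in the ring gives a 1.6-fold lower number from compound 1 to compound 3 (0.21 log units; within the scatter) in this assay, so this position accepts a larger group, one with an aromatic ring, without a change beyond the scatter. This is the first exact size for a phenyl change in the series, since compound 2, with phenyl on a saturated ring carbon, gave a limit and not a number: the limit of > 50000 nM in this assay, at which 1 of the 3 values shown sits.

From the compounds shown here alone, what stays open is whether another group on this nitrogen, such as benzyl, a longer chain or an acetyl, would move the number beyond the scatter.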